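This account rests on a few compounds, and the source may have more. Where it says the series, first, only, none or still open, it means among the compounds named here.

Measured so far:
compound 1 `CC(C)C(c1ncco1)c1ccc(-c2ccc3cccc(F)c3c2)[nH]c1=O` gives 64 nM
compound 2 `CC(C)C(c1ccc(-c2ccc3cccc(F)c3c2)[nH]c1=O)N1CCNC1=O` gives 28 nM

Both numbers come from a functional assay on CHO cells for antagonist activity at prostaglandin E2 receptor EP3 subtype (Homo sapiens), read by cAMP accumulation; a higher number here means a weaker inhibitor, a lower number a stronger inhibitor. Compound 2 stands at the lowest of the two numbers; its nearest neighbour is compound 1, and the step of a 2.3-fold lower number from compound 1 to compound 2 (0.36 log units; beyond the scatter) lies beyond the scatter.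

Compound 3 `CC(C)C(/C=C1/CCNC1=O)c1ccc(-c2ccc3cccc(F)c3c2)[nH]c1=O` differs from compound 2 in one place: a group of 7 heavy atoms (5 carbon, 1 nitrogen, 1 oxygen; one five-membered non-aromatic ring with 1 hetero atom) in place of a group of 6 heavy atoms (3 carbon, 2 nitrogen, 1 oxygen; one five-membered non-aromatic ring with 2 hetero atoms), on a saturated chain carbon bound to an aromatic carbon and a saturated chain carbon. For the measured compounds named here, no measured pair shows this exact change. Going by the values given here, the one step that bears on it at all is the swap at the same place, a 2.3-fold lower number from compound 1 to compound 2 (0.36 log units; beyond the scatter), which shows that exchanging one five-membered ring for another at this position shifts this assay only modestly. A shift of similar size, in either direction, is therefore expected for compound 3, with no firm direction from the data.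

Compound 3 is estimated at 40 nM in this assay, within 12 nM to 130 nM, which means an expected step of a 1.4-fold higher number from compound 2 to compound 3 (0.15 log units; within the scatter).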

Compound 3, half-maximal inhibitory concentration: 8.1 nM
Beside the measured number, compound 3's estimate is 4.9-fold (0.69 log units) above it, outside the stated range (below it).
By their numbers in this assay, from the lowest: compound 3; then compound 2; then compound 1.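

In this assay the group on the saturated chain carbon can do more than the earlier ring swap showed: the group in compound 3 gives a 3.5-fold lower number from compound 2 to compound 3 (0.54 log units; beyond the scatter) and, against the aromatic ring of compound 1, a 7.9-fold lower number from compound 1 to compound 3 (0.90 log units; beyond the scatter) in the same place. Both steps lie beyond the scatter, so the three compounds form a clear order at this position, and the hydrogen-bond donor and acceptor counts are the same for the groups exchanged in the step from compound 2. Nothing measured here accounts for the lower number of compound 3.

The compounds shown do not separate the effect of the ring from that of the extra double bond outside aromatic rings. They also leave open how a carboxylic acid, an amine or an open-chain amide would read in this place.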